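Aryl swap at the core of the sulfonamide series

The compounds below may be only part of what the source reports. "The series", "measured", "known", "first", "only" and "open" are said of these compounds alone.

Within the data shown here, compound 2 `COc1ccc(S(=O)(=O)N2CCc3cccc(-c4ccc(F)cc4)c32)cc1` gives 95.5 nM in a functional assay on NCI-H460 cells (Homo sapiens) for inhibition, with a stated time of 72 h (a higher number here means a weaker inhibitor, a lower number a stronger inhibitor), and stands with the highest of the three numbers measured so far; compound 1 `COc1ccc(S(=O)(=O)N2CCc3cccc(-c4cccnc4)c32)cc1` gives 89.6 nM and compound 3 `COc1ccc(S(=O)(=O)N2CCc3cccc(-c4ccc(F)c(F)c4)c32)cc1` gives 46 nM. The step of a 2.1-fold lower number from compound 2 to compound 3 (0.32 log units; beyond the scatter) is the only one beyond the scatter, while a 1.1-fold higher number from compound 1 to compound 2 (0.03 log units; within the scatter) and a 1.9-fold lower number from compound 1 to compound 3 (0.29 log units; within the scatter) stay within it.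

The step to compound 4 `COc1ccc(S(=O)(=O)N2CCc3cccc(-c4ccncc4)c32)cc1` exchanges the aryl group on the shared core: pyridin-4-yl in place of 4-fluorophenyl on an aromatic carbon. The measured step that bears on this is a 1.1-fold higher number from compound 1 to compound 2 (0.03 log units; within the scatter), in which a pyridin-3-yl and a 4-fluorophenyl gave numbers within the scatter of each other. Among the measured compounds shown here, compound 4 carries a pyridin-4-yl, an isomer of the pyridin-3-yl of compound 1, for which no step is measured, so a step beyond the scatter is not expected in this assay in either direction.

Compound 4 is therefore expected at 85 nM, within 40 nM to 180 nM, in this assay.

The step implied from compound 2 is estimated as a 1.1-fold lower number from compound 2 to compound 4 (0.05 log units; within the scatter).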

Compound 4, half-maximal inhibitory concentration: 101 nM
The estimate for compound 4 lay 1.2-fold (0.07 log units) below the measured number; low and high end bracket the measured number.
By their numbers in this assay, from the lowest: compounds 3, 1, 2 and 4 (each within the scatter of the next, the first and the last beyond it).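

In this assay, pyridin-4-yl in place of 4-fluorophenyl gives a 1.1-fold higher number from compound 2 to compound 4 (0.02 log units; within the scatter), and the change of pyridine isomer gives a 1.1-fold higher number from compound 1 to compound 4 (0.05 log units; within the scatter), so neither the swap to this isomer nor the presence of a ring hetero atom separates these compounds at this aromatic carbon. Among these compounds, the one step from compound 4 beyond the scatter is the modest 2.2-fold higher number from compound 3 to compound 4 (0.34 log units; beyond the scatter), which sets pyridin-4-yl apart from 3,4-difluorophenyl, though the second fluoro remains a small gain over a narrow range rather than a broad pattern, and compound 1 stays within the scatter of compound 3. Nothing available explains why these aryl groups behave so alike.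

Still open, going by these compounds, is whether an aryl ring carrying an amine or a carboxylic acid would stay in this range. A saturated ring such as piperidine at the same carbon is equally unresolved, as is any change to the methoxy group on the sulfonyl aryl ring.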